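Varying the arm on the amine-bound chain carbon

The compounds below may be only part of what the source reports. "The series", "measured", "known", "first", "only" and "open" are said of these compounds alone.

Compound 1 `O=S(=O)(NCCCNCc1cccc2ccccc12)c1cc(C(F)(F)F)cc(C(F)(F)F)c1` carries naphthalen-1-yl on the saturated chain carbon bound to the amine nitrogen, and in a functional assay on BE(2)-C cells (Homo sapiens) for inhibition, read by MTT assay, with a stated time of 72 h (a lower number here means a stronger inhibitor of growth, a higher number a weaker inhibitor of growth), compound 1 gives 2700 nM. Compound 2 `O=S(=O)(NCCCNCc1ccc(Cl)cc1)c1cc(C(F)(F)F)cc(C(F)(F)F)c1` gives 2900 nM in this assay, and compound 3 `CC(C)(C)c1ccc(CNCCCNS(=O)(=O)c2cc(C(F)(F)F)cc(C(F)(F)F)c2)cc1` gives 2500 nM. On these three numbers compound 1 stands second highest, but every pairing is within the scatter: a 1.1-fold higher number from compound 1 to compound 2 (0.03 log units; within the scatter), a 1.1-fold lower number from compound 1 to compound 3 (0.03 log units; within the scatter), and also a 1.2-fold lower number from compound 2 to compound 3 (0.06 log units; within the scatter). So far, swapping the group at this place has not moved the number beyond the scatter.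

Compound 4 `O=S(=O)(NCCCNCC1COc2ccccc2O1)c1cc(C(F)(F)F)cc(C(F)(F)F)c1` is the next member. It differs from compound 1 by 2,3-dihydro-1,4-benzodioxin-2-yl in place of naphthalen-1-yl on a saturated chain carbon bound to an amine nitrogen. Among the measured compounds shown here, the steps that bear on this change are the two swaps at the same place already given, each within the scatter. For the measured compounds named here, the entering group is unlike the earlier replacements in having one non-aromatic ring with hetero atoms and two hydrogen-bond acceptors; no measured compound tests such a group, so this remains an assumption carried over from the measured swaps. The expectation is therefore a step of a 1.0-fold higher number from compound 1 to compound 4 (0.02 log units; within the scatter), not beyond the scatter. Compound 4 is expected to give 2800 nM in this assay, with a range from 1200 nM to 6500 nM.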

Compound 4, concentration for 50% growth inhibition: 2800 nM
Beside the measured number, compound 4's estimate shows no gap at the digits printed; low and high end bracket the measured number.
By their numbers in this assay, from the lowest: compounds 3, 1, 4 and 2 (each within the scatter of the next).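

In this assay, the change to 2,3-dihydro-1,4-benzodioxin-2-yl gives a 1.0-fold higher number from compound 1 to compound 4 (0.02 log units; within the scatter) and shows that an arm with a non-aromatic ring holding two hetero atoms and two hydrogen-bond acceptors, a kind not seen in compounds 1 to 3, also leaves the number within the scatter at this place on a saturated chain carbon bound to an amine nitrogen. The comparisons with the two phenyl arms agree, with a 1.1-fold higher number from compound 3 to compound 4 (0.05 log units; within the scatter) and a 1.0-fold lower number from compound 2 to compound 4 (0.02 log units; within the scatter), so among compounds 1 to 4 no swap at this place moves the number beyond the scatter, whether the arm is fully aromatic or partly saturated with ring oxygens. Nothing available explains this flat result.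

Still open, as far as these compounds go, is whether any other arm at this place would move the number beyond the scatter, for example pyridin-3-yl, a carboxylic acid on the phenyl ring, or a plain methyl. The compounds shown also leave open what changes elsewhere in the core of compound 1 would do, such as a longer chain in the linker or a nitrile in place of a trifluoromethyl.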